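This account rests on a few compounds, and the source may have more. Where it says the series, first, only, none or still open, it means among the compounds named here.

Within the data shown here, in a functional assay on A549 cells (Homo sapiens) for antiproliferative activity, read by MTT assay, with a stated time of 72 h (a higher number here means a weaker inhibitor, a lower number a stronger inhibitor), compound 2 `O=C(Nc1ccc(Cl)c(-c2nnc3c(Cl)cccn23)c1)c1cccnc1Cl` gives 35800 nM, the only actual number reported in this set. Compound 1 `Cc1nc(C(=O)Nc2ccc(Cl)c(-c3nnc4c(Cl)cccn34)c2)cs1` gives > 100000 nM, which is a limit of the assay rather than a number. Among the measured compounds shown here, the step of an at least 2.7-fold lower number from compound 1 to compound 2 (0.44 log units; beyond the scatter) is the single measured change, and one of its two ends sits at the limit of > 100000 nM in this assay, at which 1 of the 2 values shown sits, so its size is known only as a lower bound. Compound 3 `O=C(Nc1ccc(Cl)c(-c2nnc3c(Cl)cccn23)c1)c1ccccc1` differs from compound 2 by phenyl in place of 2-chloropyridin-3-yl on a carbonyl carbon. The measured step also exchanged the group on the carbonyl carbon and moved the number beyond the scatter; the change to compound 3 strips the ring nitrogen and the chlorine counted in the leaving group, so a drift toward a higher number seems somewhat more likely than toward a lower one, though it may well stay within the scatter. Compound 3 is therefore expected to give 50000 nM, in the range 15000 nM to 200000 nM. The expected step is a 1.4-fold higher number from compound 2 to compound 3 (0.15 log units; within the scatter).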

Compound 3, half-maximal inhibitory concentration: 76900 nM
Beside the measured number, compound 3's estimate is 1.5-fold (0.19 log units) below it; the range from low to high includes it.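

In this assay, the step of a 2.1-fold higher number from compound 2 to compound 3 (0.33 log units; beyond the scatter) shows that this place on the carbonyl carbon responds to a small exchange: 2-chloropyridin-3-yl and phenyl are not interchangeable there, although the change is only modest. Compound 1 stands at a limit of the assay rather than at a number: the limit of > 100000 nM in this assay, at which 1 of the 3 values shown sits. The step of an at least 1.3-fold lower number from compound 1 to compound 3 (0.11 log units; that floor lies within the scatter) therefore has a floor that does not separate phenyl from 2-methyl-1,3-thiazol-4-yl.

The exchange from compound 2 to compound 3 removes the ring nitrogen and the chlorine together, so the compounds shown cannot say which of the two carries the step; a pyridin-3-yl or a 2-chlorophenyl group would divide them. On these data alone, how a saturated group such as piperidinyl would read on the same carbonyl carbon also stays open.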